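Swapping the pyridine back for a substituted phenyl ring

The source may report more compounds than this note shows. Statements on the series, on what has been measured and on what is new or still open speak of the compounds shown alone.

Compound 1 `C=C1C[C@]23C[C@@]1(O)CC[C@H]2c1cc(Br)c(O)c(C)c1[C@@H]3Cn1cc(-c2ccc(F)cc2)nn1` carries a 4-fluorophenyl group on the shared core; in a functional assay on HL-60 cells (Homo sapiens) for cytotoxicity, read by MTT assay, with a stated time of 4 days (on this read-out lower numbers stand for stronger inhibition and higher numbers for weaker inhibition), compound 1 gives 6600 nM. Compound 2 `C=C1C[C@]23C[C@@]1(O)CC[C@H]2c1cc(Br)c(O)c(C)c1[C@@H]3Cn1cc(-c2ccccn2)nn1` carries pyridin-2-yl instead. In this assay compound 2 reaches only a limit of the assay, > 20000 nM. The step of an at least 3.0-fold higher number from compound 1 to compound 2 (0.48 log units; beyond the scatter) thus rests on (the limit of > 20000 nM in this assay, at which 1 of the 2 values shown sits). Compound 3 `C=C1C[C@]23C[C@@]1(O)CC[C@H]2c1cc(Br)c(O)c(C)c1[C@@H]3Cn1cc(-c2ccc(C(F)(F)F)cc2)nn1` makes the change (4-(trifluoromethyl)phenyl in place of pyridin-2-yl on an aromatic carbon), bringing back a six-membered aromatic ring of carbon only. Among the compounds with values here, because the one measured step of an at least 3.0-fold higher number from compound 1 to compound 2 (0.48 log units; beyond the scatter) shows the pyridine weakening, a return toward the value of compound 1 is expected, so for compound 3 the expected step is an at least 2.5-fold lower number from compound 2 to compound 3 (0.39 log units; beyond the scatter). The estimate for compound 3 is 8000 nM, within 3000 nM to 20000 nM.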

Compound 3, half-maximal inhibitory concentration: 7380 nM
Estimate against measurement, compound 3: 1.1-fold (0.04 log units) above, and the stated range covers the measured number.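

With 4-(trifluoromethyl)phenyl at this position, this assay shows an at least 2.7-fold lower number from compound 2 to compound 3 (0.43 log units; beyond the scatter), so a second phenyl ring with a substituent also stands clear of pyridin-2-yl. Going by these compounds, the size of that step stays open-ended: the limit of > 20000 nM in this assay, at which 1 of the 3 values shown sits. Exchanging fluoro for trifluoromethyl on the phenyl ring gives a 1.1-fold higher number from compound 1 to compound 3 (0.05 log units; within the scatter), so this assay does not tell the two groups apart.

The compounds shown leave open whether a phenyl ring bearing an amine or a carboxylic acid would hold this level. They also leave open whether any group here could give a much lower number.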